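Replacing the Ring on the Sulfur of Compound 1

A few compounds are considered here, and "the series" means these few. Any claim that something is new, unique, unknown or untested is made for them only; others in the source may bear on it.

Two compounds have been measured in a functional assay on C6 cells (Rattus norvegicus) for cytotoxicity, read by MTT assay, with a stated time of 24 h, tested at 12 ug/mL; a lower number here means a stronger effect, a higher number a weaker effect of the compound at the concentration tested:

compound 1, `O=C(CSc1nnnn1-c1ccccc1)N/N=c1/scc(-c2ccccc2)n1-c1ccccc1`, giving 47.1%
compound 2, `O=C(CSc1nnnn1-c1ccccc1)N/N=c1/scc(-c2ccc(Cl)cc2)n1-c1ccccc1`, giving 69.3%

Compound 1 stands lowest of these two numbers, which in this assay means the stronger effect on the cells. Among the measured compounds shown here, its nearest neighbour is compound 2, and the single measured step, a number 22.2 percentage points higher from compound 1 to compound 2 (beyond the scatter), comes from chloro in place of hydrogen on an aromatic carbon.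

The next compound, compound 3, `Cc1nnc(SCC(=O)N/N=c2/scc(-c3ccccc3)n2-c2ccccc2)s1`, is changed at a different spot. Compared with compound 1, the difference is 5-methyl-1,3,4-thiadiazol-2-yl in place of 1-phenyl-1H-tetrazol-5-yl on a sulfur. For the measured compounds named here, the one measured step concerns the ring on the aromatic carbon, not the group on the sulfur, so no measured step bears on this change. With nothing to pull the number either way, the expected step is none beyond the scatter, though with a wide margin of doubt. Compound 3 is therefore estimated at 50%, in a range from 28% to 75%, which means an expected a number 2.9 percentage points higher from compound 1 to compound 3 (within the scatter).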

Compound 3, a percentage reported as activity, at one concentration (the size of the read-out at that concentration, not a potency): 72.5%
Compound 3: middle estimate off by 22.5 percentage points, on the low side; the range from low to high includes it.
By their numbers in this assay, from the lowest: compound 1; then compounds 2 and 3 (each within the scatter of the next).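

The group on the sulfur matters in this assay: 5-methyl-1,3,4-thiadiazol-2-yl in place of 1-phenyl-1H-tetrazol-5-yl gives a number 25.4 percentage points higher from compound 1 to compound 3 (beyond the scatter), and a higher number here means a weaker effect on the cells. Among the compounds shown here, until now the only measured step was the chloro in place of hydrogen on an aromatic carbon, so this is a second place in the molecule where a change moves the number, and both changes leave compound 1 with the strongest effect of the three. The swap alters the ring, its hetero atoms and the total size all at once, and no available data explain why the number rises.

The compounds shown do not separate the part played by the ring from that of its methyl or of the phenyl that leaves, which a 1-methyl-1H-tetrazol-5-yl or an unsubstituted 1,3,4-thiadiazol-2-yl on the sulfur could address. Also open, on these data alone, is whether a non-ring group on the sulfur, such as a benzyl or a short alkyl chain ending in an amine, would keep the effect of compound 1.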